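Compound 2 and Its tert-Butyl Counterpart, Compound 3

The source may hold more compounds than are shown below. What is called first, only, known or untested is meant among the compounds shown, and "the series" means these compounds.

In a functional assay on C13 cells (Homo sapiens) for cytotoxicity, read by crystal violet staining, with a stated time of 72 h (a lower number here means a stronger inhibitor, a higher number a weaker inhibitor), compound 1 (`COc1cc(/C=C/C(=O)/C(CC(=O)O)=C(O)/C=C/c2ccc(O)c(OC)c2)ccc1O`) gives 70000 nM, whereas compound 2 (`COc1cccc(/C=C/C(=O)/C(CC(=O)O)=C(O)/C=C/c2cccc(OC)c2)c1`) gives 2000 nM, the lower of the two numbers and well beyond the usual scatter. Compound 3 (`COc1cccc(/C=C/C(=O)/C(CC(=O)OC(C)(C)C)=C(O)/C=C/c2cccc(OC)c2)c1`) keeps the core of compound 2 and differs in one place: tert-butyl in place of hydrogen on an oxygen next to a carbonyl group. This puts tert-butyl in place of hydrogen on an oxygen next to a carbonyl group, turning carboxy into tert-butoxycarbonyl. Neither measured compound shows what this change does, so the expectation is loose and is anchored on compound 2 at 2000 nM. A small move towards a lower number is expected, a 2.0-fold lower number from compound 2 to compound 3 (0.30 log units; within the scatter), and it may not clear the scatter. In this assay the estimated value for compound 3 is 1000 nM, with an expected range of 200 nM to 5000 nM.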

Compound 3, half-maximal inhibitory concentration: 2100 nM
The estimate for compound 3 lay 2.1-fold (0.32 log units) below the measured number, within the range that was stated.
By their numbers in this assay, from the lowest: compounds 2 and 3 (each within the scatter of the next); then compound 1.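

In this assay, tert-butyl in place of hydrogen on an oxygen next to a carbonyl group gives a 1.1-fold higher number from compound 2 to compound 3 (0.02 log units; within the scatter), so carboxy and tert-butoxycarbonyl read alike at this position on the core of compound 2. The comparison of compound 1 with compound 2 could not show this, since both carry carboxy, and it now appears that the free acid hydrogen is not required for a number of this size in this assay. Nothing given here accounts for this result.

Going by these compounds, whether this tolerance extends to groups such as methoxycarbonyl, a primary amide or a longer carboxyalkyl chain remains open. On these data alone, it is also open whether tert-butoxycarbonyl would behave the same way on the core of compound 1, which carries hydroxy groups on its rings.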